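This account rests on a few compounds, and the source may have more. Where it says the series, first, only, none or still open, it means among the compounds named here.

Compound 1 `COc1cccc(-c2ncnn2-c2cc(OC)c(OC)c(OC)c2)c1` and compound 2 `COc1cc(-n2ncnc2-c2cccc([N+](=O)[O-])c2)cc(OC)c1OC` share one core that carries a trimethoxyphenyl group on one side and a second aryl group on the other. In a functional assay on MCF7 cells (Homo sapiens) for antiproliferative activity, read by MTT assay, with a stated time of 72 h (on this read-out lower numbers stand for stronger inhibition and higher numbers for weaker inhibition), compound 1 gives only a limit of the assay, > 10000 nM. Compound 2 likewise gives only a limit in this assay, > 10000 nM. For the measured compounds named here, the one measured step, a step that the two limits leave unreadable from compound 1 to compound 2, cannot be read because the limit of > 10000 nM in this assay, at which 2 of the 2 values shown sit, leaves no number on either side of it. Compound 3 `COc1cc(-n2ncnc2-c2ccc(F)cc2)cc(OC)c1OC` differs from compound 1 by 4-fluorophenyl in place of 3-methoxyphenyl on an aromatic carbon. No measured step bears directly on this change; the only comparison available, the one between compound 1 and compound 2, is itself unreadable, so nothing shown points toward a step in either direction beyond the usual scatter. Compound 3 is therefore expected to give about 12000 nM in this assay, with a range from 3000 nM to 40000 nM, and most likely again only as a limit. The step this estimate means, a step that the limit leaves unreadable from compound 1 to compound 3, is expected to be small or not readable at all.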

Compound 3, half-maximal inhibitory concentration: > 10000 nM
Compound 3 ended at the assay's limit; the forecaster's own chance of this, stated with the estimate: 70%; the middle value is on the limit's open side.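

No new step can be read from compound 3: like compound 1 and compound 2, it gives only a limit, because all three values end at the same point: the limit of > 10000 nM in this assay, at which 3 of the 3 values shown sit.

The compounds shown leave open how 4-fluorophenyl and 3-methoxyphenyl compare on the shared core, and whether any of the three has a measurable potency in this assay.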